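The compounds below may be only part of what the source reports. "The series", "measured", "known", "first", "only" and "open" are said of these compounds alone.

Of the compounds shown here, three built on the same core have been measured so far. Compound 1 is `CO[C@@H]1[C@@H](O)[C@@H](O)[C@H]2O[C@]1(C)n1c3ccccc3c3c4c(c5c6ccccc6n2c5c31)C(=O)NC4`, compound 2 is `CO[C@H]1C(=O)C[C@H]2O[C@]1(C)n1c3ccccc3c3c4c(c5c6ccccc6n2c5c31)C(=O)NC4`, and compound 3 is `CO[C@@H]1[C@H](N(C)C=O)C[C@H]2O[C@]1(C)n1c3ccccc3c3c4c(c5c6ccccc6n2c5c31)C(=O)NC4`. In an assay on isolated protein for inhibition of protein kinase C theta type (Homo sapiens), read by HTRF (a higher number here means a weaker inhibitor, a lower number a stronger inhibitor), compound 1 gives 1010 nM. In this assay compound 2 gives 560 nM, and compound 3 gives 250 nM. Compound 3 therefore stands lowest of the three numbers, which in this read-out means the strongest inhibition: its nearest neighbour is compound 2, whose number is higher by a margin beyond the usual scatter, and the furthest is compound 1, whose number lies higher still, again beyond the scatter. Among the compounds with values here, none of these three pairs differs in only one place, so no single clean step between measured compounds is available.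

Compound 4 is `CO[C@@H]1[C@H](N(C)C(N)=O)C[C@H]2O[C@]1(C)n1c3ccccc3c3c4c(c5c6ccccc6n2c5c31)C(=O)NC4`. It differs from compound 3 in one place: amino in place of hydrogen on a carbonyl carbon. Within the data shown here, nothing among the measured compounds shows what such a change does in this assay, so the expectation rests only on the small size of the change. The step from compound 3 to compound 4 is expected to be small, no change at the digits printed from compound 3 to compound 4 (within the scatter), and likely not beyond the scatter in either direction. Compound 4 is accordingly estimated at 250 nM, within a range from 100 nM to 650 nM.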

Compound 4, half-maximal inhibitory concentration: 400 nM
For compound 4 the middle estimate is 1.6-fold (0.20 log units) below the measured one; measured number inside the range.
By their numbers in this assay, from the lowest: compounds 3, 4, 2 and 1 (each within the scatter of the next, the first and the last beyond it).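

In this assay, within the data shown here, this pair gives the first clean comparison at this place on the shared core, and the step reads a 1.6-fold higher number from compound 3 to compound 4 (0.20 log units; within the scatter). Formyl(methyl)amino and carbamoyl(methyl)amino therefore cannot be told apart here: adding amino in place of hydrogen on a carbonyl carbon, with its one extra hydrogen-bond donor, produces no difference that stands clear of the usual scatter of repeated measurements. No measurement is available that could explain this result.

The compounds shown leave open whether the carbonyl is needed at all, which a plain methylamino group would test, and what a larger group on that carbonyl carbon, such as methyl, methoxy or a longer chain, would do. As far as these compounds go, the part played by this group in the numbers of compound 3 and compound 4 also remains unknown, as compound 1 and compound 2 differ from them in more than one place and those comparisons cannot be read as single steps.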